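Benzyl for Cyclohexyl: One Change Across Two Cores

The compounds below may be only part of what the source reports. "The series", "measured", "known", "first", "only" and "open" are said of these compounds alone.

Three compounds have been measured in a functional assay on RPMI-8226 cells (Homo sapiens) for inhibition, read by sulforhodamine B assay, with a stated time of 48 h, tested at 10 uM; a lower number here means less inhibition, a higher number more inhibition at the concentration tested (going by the name of the read-out):

Compound 1, `c1ccc2c(-c3cn4ccnc4c(-c4ccc5ncn(C6CCCCC6)c5c4)n3)cccc2c1`: 22.9%
Compound 2, `c1ccc(Cn2cnc3ccc(-c4nc(-c5cccc6ccccc56)cn5ccnc45)cc32)cc1`: 26.9%
Compound 3, `c1cn2cc(-c3ccc4c(c3)ncn4C3CCCCC3)nc(-c3ccc4ncn(C5CCCCC5)c4c3)c2n1`: 70.8%

Compound 2 differs from compound 1 in one place, (benzyl in place of cyclohexyl on an aromatic nitrogen). In this assay this change gave a number 4 percentage points higher from compound 1 to compound 2 (within the scatter), so compound 1 and compound 2 cannot be told apart by this read-out. Compound 3 stands highest of the three, beyond the scatter from both compound 1 and compound 2. How the core of compound 3 differs from the core of compound 1 is not broken down here.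

Compound 4, `c1ccc(Cn2cnc3ccc(-c4nc(-c5ccc6c(c5)ncn6C5CCCCC5)cn5ccnc45)cc32)cc1`, has not yet been measured. It differs from compound 3 by benzyl in place of cyclohexyl on an aromatic nitrogen, the same change that leads from compound 1 to compound 2.

Because the earlier step was a number 4 percentage points higher from compound 1 to compound 2 (within the scatter), the step of a number 1.8 percentage points lower from compound 3 to compound 4 (within the scatter) is expected to be small as well, though this rests on a single pair of compounds whose values lie far below that of compound 3. Compound 4 is estimated to give 69% in this assay, expected between 50% and 85%.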

Compound 4, a percentage reported as inhibition, at one concentration (the size of the read-out at that concentration, not a potency): -41.2%
Compound 4: the middle estimate sits 110.2 percentage points above what was measured, and the stated range ends above it.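

Benzyl in place of cyclohexyl on an aromatic nitrogen gave in this assay a number 112 percentage points lower from compound 3 to compound 4 (beyond the scatter), so the change did not behave alike on the two cores: the same change on two cores in this assay, a number 4 percentage points higher (within the scatter) from compound 1 to compound 2 and a number 112 percentage points lower (beyond the scatter) from compound 3 to compound 4, 116 percentage points apart, beyond the scatter of two such steps

For the compounds shown here, for these two pairs, then, the outcome of the change depended on the core that carried it, and the small step on the core of compound 1 gave no guide to the step on the core of compound 3. The two pairs do not show which feature of the cores sets this difference, why the change acts as it does, or whether the same contrast would hold at other concentrations, as each reading comes from a single concentration in one cell line.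

On these data alone, it remains open whether another group on that nitrogen, such as a longer alkyl chain, a chain ending in an amine or one ending in a carboxylic acid, would bring a step as large as benzyl did on the core of compound 3. Also open, as far as these compounds go, is what happens on that core when benzyl stands in place of both cyclohexyl groups of compound 3.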